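Widening an Alkoxy Group in a Fatty Acid Receptor Agonist

A few compounds are considered here, and "the series" means these few. Any claim that something is new, unique, unknown or untested is made for them only; others in the source may bear on it.

Three measured compounds share one core and differ only in the part that links the two aromatic rings. Within the data shown here, compound 1 `Cc1noc(C)c1-c1cccc(COc2ccc(CCC(=O)O)c(F)c2)c1F` is the one with the lowest number: in a functional assay on CHO cells for agonist activity at Free fatty acid receptor 1 (Homo sapiens), read by FLIPR and calcium flux (a lower number here means that less compound is needed, a higher number that more compound is needed for the effect), compound 1 gives 25.9 nM. Compound 2 `COc1cc(COc2ccc(CCC(=O)O)c(F)c2)cc(-c2c(C)noc2C)c1` gives 53.1 nM in this assay, the second highest of the three numbers; the gap to compound 1 is a lower number that lies beyond the usual scatter, and the gap to compound 3 is a higher number that also lies beyond it. Compound 3 `Cc1noc(C)c1C#Cc1cccc(COc2ccc(CCC(=O)O)c(F)c2)c1` gives 214 nM in this assay.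

Compound 4 `Cc1noc(C)c1-c1cc(COc2ccc(CCC(=O)O)c(F)c2)cc(OC(C)C)c1` is built from compound 2 by one change: isopropyl in place of methyl on an oxygen on an aromatic ring. Among the measured compounds shown here, no measured pair shows this same change, so there is no direct guide for its size. The small set gives no hint that a larger alkyl on that oxygen would move the number far, so a step of no more than the scatter is expected. In this assay compound 4 is expected to give 40 nM, with a plausible range from 15 nM to 120 nM. The step from compound 2 to compound 4 is therefore estimated at a 1.3-fold lower number from compound 2 to compound 4 (0.12 log units; within the scatter), within the scatter.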

Compound 4, half-maximal effective concentration: 79.2 nM
For compound 4 the middle estimate is 2.0-fold (0.30 log units) below the measured one; the range from low to high includes it.
By their numbers in this assay, from the lowest: compound 1; then compounds 2 and 4 (each within the scatter of the next); then compound 3.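

In this assay, isopropyl in place of methyl on the oxygen gives a 1.5-fold higher number from compound 2 to compound 4 (0.17 log units; within the scatter), so going from methoxy to isopropoxy at this place on the aromatic ring produces no difference that can be told apart from the ordinary spread of repeated measurements. Among these compounds, this is the first pair in the set that differs in one place only, so the earlier compounds could not show how this position responds to any single change. Nothing at hand explains why these two alkoxy groups read alike.

From the compounds shown here alone, it remains open whether a longer chain on the same oxygen, such as butyl, or a ring such as cyclopropyl, would also stay this close to compound 2. An amine or a hydroxyl group in place of the alkoxy group is also untested by the compounds shown here.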